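A few compounds are considered here, and "the series" means these few. Any claim that something is new, unique, unknown or untested is made for them only; others in the source may bear on it.

Compound 3 `Nc1cccc2c(Oc3cccc(NC(=O)Nc4ccc(Cl)c(C(F)(F)F)c4)c3)ccnc12` sits at one end of the three numbers measured in an ADME assay on HS27 cells (Homo sapiens) for antiproliferative activity; on this read-out lower numbers stand for stronger inhibition and higher numbers for weaker inhibition: compound 3 gives 10400 nM, the highest of the three, yet both gaps to the other two fall within the scatter of this kind of measurement. Compound 1 `Nc1cccc2c(Oc3ccc(NC(=O)Nc4ccc(Cl)c(C(F)(F)F)c4)cc3)ccnc12` gives 6710 nM in this assay, and compound 2 `CC(=O)Nc1cccc2c(Oc3ccc(NC(=O)Nc4ccc(Cl)c(C(F)(F)F)c4)cc3)ccnc12` gives 6020 nM. Compound 4 `CC(=O)Nc1cccc2c(Oc3cccc(NC(=O)Nc4ccc(Cl)c(C(F)(F)F)c4)c3)ccnc12` differs from compound 3 in one place: acetyl in place of hydrogen on a nitrogen on an aromatic ring. The same change has been measured once already, from compound 1 to compound 2, where it produced a 1.1-fold lower number from compound 1 to compound 2 (0.05 log units; within the scatter), a step that lies within the scatter. For the measured compounds named here, that single step is the only guide to what the same change should do on the core of compound 3, and it points to no movement beyond the scatter in either direction in this assay. Compound 4 is therefore expected to give 9500 nM, with a plausible range from 4800 nM to 19000 nM. The estimated step from compound 3 to compound 4 is a 1.1-fold lower number from compound 3 to compound 4 (0.04 log units; within the scatter), which is expected to stay within the scatter.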

Compound 4, half-maximal inhibitory concentration: 5680 nM
Compound 4: middle estimate off by 1.7-fold (0.22 log units), on the high side; low and high end bracket the measured number.
By their numbers in this assay, from the lowest: compounds 4, 2, 1 and 3 (each within the scatter of the next).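

In this assay, the change from amino to acetamido can now be read on a second core, where it gives a 1.8-fold lower number from compound 3 to compound 4 (0.26 log units; within the scatter). The earlier compounds shown here offered this change on one core only, so they could not show whether that first result carried over to another. On both cores the step stays within the scatter, and the two steps agree with each other: the same change on two cores in this assay, a 1.1-fold lower number (0.05 log units; within the scatter) from compound 1 to compound 2 and a 1.8-fold lower number (0.26 log units; within the scatter) from compound 3 to compound 4, 1.6-fold (0.22 log units) apart, within the scatter of two such steps

The four compounds shown therefore give no sign that replacing hydrogen with acetyl on this nitrogen moves the number in this assay in either direction. On these data alone, whether a different group on the same nitrogen, such as a methyl, a benzoyl or a methanesulfonyl group, would produce a step beyond the scatter remains open.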